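Benzylamino in Place of 4-Methylpiperidin-1-yl

The source may report more compounds than this note shows. Statements on the series, on what has been measured and on what is new or still open speak of the compounds shown alone.

Compound 1 `CC(C)n1cnc2c(Nc3ccccc3)nc(NCOCc3ccc(/C=C/C(=O)Nc4ccccc4N)cc3)nc21` gives 41% in a functional assay on NCI-H460 cells (Homo sapiens) for antiproliferative activity, read by CCK-8 assay, with a stated time of 72 h, tested at 2 uM; on this read-out lower numbers stand for a weaker effect and higher numbers for a stronger effect at the one concentration tested. Compound 2 `CC1CCN(c2nc(Cl)nc3c2ncn3Cc2ccc(/C=C/C(=O)Nc3ccccc3N)cc2)CC1` gives 8.24% in this assay. Compound 3 `CC1CCN(c2nc(Cl)nc3c2ncn3Cc2ccc(C(=O)Nc3ccccc3N)cc2)CC1` gives 11.8% in this assay.

Compound 2 stands lowest of the three numbers. Its nearest neighbour is compound 3, and that step, a number 3.6 percentage points higher from compound 2 to compound 3 (within the scatter), lies within the scatter. Compound 1 is furthest away, with a number that is beyond the scatter above compound 2, but compound 1 differs from compound 2 in more than one place, so no single change can be read from it.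

Compound 4 `Nc1ccccc1NC(=O)/C=C/c1ccc(Cn2cnc3c(NCc4ccccc4)nc(Cl)nc32)cc1` differs from compound 2 in one place: benzylamino in place of 4-methylpiperidin-1-yl on an aromatic carbon. Among the compounds with values here, no measured step changes this position; the only one-place step known, from compound 2 to compound 3, concerns the linker to the (2-aminophenyl)carbamoyl group and does not bear on this exchange. There is therefore no ground to expect a step beyond the scatter in this assay, in either direction, and the range must stay wide. For compound 4 the expected value is 14%, between 4% and 32%, which would be an estimated step of a number 5.8 percentage points higher from compound 2 to compound 4 (within the scatter).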

Compound 4, a percentage reported as inhibition, at one concentration (the size of the read-out at that concentration, not a potency): 4.62%
Estimate against measurement, compound 4: 9.4 percentage points above; low and high end bracket the measured number.
By their numbers in this assay, from the lowest: compounds 4, 2 and 3 (each within the scatter of the next); then compound 1.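

Benzylamino in place of 4-methylpiperidin-1-yl gives, in this assay, a number 3.6 percentage points lower from compound 2 to compound 4 (within the scatter). Within the data shown here, this is the first measured change at this position. It shows that a non-aromatic ring with no hydrogen-bond donor and a group bringing an aromatic ring of carbon only and a hydrogen-bond donor give readings that cannot be told apart at the one concentration tested. Nothing measured here offers an explanation for this outcome.

On these data alone, it remains open whether a morpholin-4-yl group, or a longer chain such as phenethylamino, on this aromatic carbon would move the number beyond the scatter. As far as these compounds go, it is also open whether the same exchange would give a similar result in the setting of compound 3.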